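Moving from a 4-bromophenyl amide to a 3-methylphenyl amide

The compounds below may be only part of what the source reports. "The series", "measured", "known", "first", "only" and "open" are said of these compounds alone.

Compound 1 `CN(C)C(=O)c1cc2cnc(Nc3ccc(NC(=O)C4(C(=O)Nc5ccc(Br)cc5)CC4)cc3)nc2n1C1CCCC1` gives -6.6% in a functional assay on A549 cells (Homo sapiens) for inhibition, read by CCK-8 assay, with a stated time of 72 h, tested at 1 uM (a lower number here means less inhibition of growth, a higher number more inhibition of growth at the concentration tested), the lowest of the three measured numbers. Compound 2 `CN(C)C(=O)c1cc2cnc(Nc3ccc(NC(=O)C4(C(=O)Nc5cccc(Br)c5)CC4)cc3)nc2n1C1CCCC1` gives 20.2% and compound 3 `CN(C)C(=O)c1cc2cnc(Nc3ccc(NC(=O)C4(C(=O)Nc5ccc(O)cc5)CC4)cc3)nc2n1C1CCCC1` gives 93.6%. Compound 4 `Cc1cccc(NC(=O)C2(C(=O)Nc3ccc(Nc4ncc5cc(C(=O)N(C)C)n(C6CCCC6)c5n4)cc3)CC2)c1` differs from compound 1 as follows: 3-methylphenyl in place of 4-bromophenyl on an amide-type nitrogen. For the measured compounds named here, two measured steps bear on it. The closer one is a number 26.8 percentage points higher from compound 1 to compound 2 (beyond the scatter), a modest rise that also moves the substituent to a 3-substituted ring. The larger one, a number 100.2 percentage points higher from compound 1 to compound 3 (beyond the scatter), exchanges bromo for hydroxy, which compound 4 does not do. A modest rise is therefore expected, a number 26.6 percentage points higher from compound 1 to compound 4 (beyond the scatter), giving an estimate for compound 4 of 20% with a range from -10% to 55%.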

Compound 4, percent growth inhibition at one concentration: 35.2%
Compound 4: middle estimate off by 15.2 percentage points, on the low side; measured number inside the range.
By their numbers in this assay, from the lowest: compound 1; then compound 2; then compound 4; then compound 3.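

With the ring position held, methyl in place of bromo gives a number 15 percentage points higher from compound 2 to compound 4 (beyond the scatter) in this assay, so the substituent itself matters on this amide, not only where it sits. The full change gives a number 41.8 percentage points higher from compound 1 to compound 4 (beyond the scatter) and, measured against the hydroxy compound, a number 58.4 percentage points lower from compound 3 to compound 4 (beyond the scatter), so the 3-methylphenyl amide recovers only part of the ground between the 4-bromophenyl and 4-hydroxyphenyl amides. Nothing shown here accounts for these differences.

From the compounds shown here alone, it remains open whether hydroxy keeps its high number on the 3-substituted ring, as a 3-hydroxyphenyl amide would show. Going by these compounds, it is equally open whether an amine or a carboxylic acid on this ring would come close to compound 3.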